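A few compounds are considered here, and "the series" means these few. Any claim that something is new, unique, unknown or untested is made for them only; others in the source may bear on it.

Notes on the series. Compound 1 `FC(F)(F)c1cc(/N=N/Nc2ccc(Cl)c(C(F)(F)F)c2)ccc1Cl` gives 58400 nM in a functional assay on HeLa cells (Homo sapiens) for cytotoxicity, read by MTT assay, with a stated time of 72 h; on this read-out higher numbers stand for weaker inhibition and lower numbers for stronger inhibition. Compound 2 `O=[N+]([O-])c1ccc(/N=N/Nc2ccc([N+](=O)[O-])cc2Br)c(Br)c1` gives 940 nM in this assay, and compound 3 `O=C(c1ccccc1)N(/N=N/c1ccc([N+](=O)[O-])cc1Br)c1ccc([N+](=O)[O-])cc1Br` gives 1530 nM in this assay. Compound 3 thus stands second highest of the three numbers: its neighbour is compound 2, within the scatter, while compound 1 lies far above it. Among the compounds with values here, the only step measured in one place is a 1.6-fold higher number from compound 2 to compound 3 (0.21 log units; within the scatter), in which a benzoyl replaces the hydrogen on the nitrogen; it changes little.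

Compound 4 `O=C(c1cccc(C(F)(F)F)c1)N(/N=N/c1ccc([N+](=O)[O-])cc1Br)c1ccc([N+](=O)[O-])cc1Br` is not yet measured. It differs from compound 3 by trifluoromethyl in place of hydrogen on an aromatic carbon, placed on the benzoyl ring, meta to a large group. Within the data shown here, no measured step touches the benzoyl ring itself, so nothing bears directly on this change; compound 1 carries trifluoromethyl groups, but on a different core, and its value offers no step to compare. The benzoyl addition itself, seen in a 1.6-fold higher number from compound 2 to compound 3 (0.21 log units; within the scatter), stayed within the scatter, so a further change on that ring is expected to move the number little. Compound 4 is therefore expected near 1500 nM, with a range from 600 nM to 4000 nM, the expected step being a 1.0-fold lower number from compound 3 to compound 4 (0.01 log units; within the scatter), none beyond the scatter.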

Compound 4, half-maximal inhibitory concentration: 1120 nM
Compound 4: middle estimate off by 1.3-fold (0.13 log units), on the high side, and the stated range covers the measured number.
By their numbers in this assay, from the lowest: compounds 2, 4 and 3 (each within the scatter of the next); then compound 1.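

In this assay the change from phenyl to 3-(trifluoromethyl)phenyl gives a 1.4-fold lower number from compound 3 to compound 4 (0.14 log units; within the scatter) and so stays within the scatter. Within the data shown here, this is the first measured change on the benzoyl ring itself: the earlier compounds showed only the addition of the whole benzoyl, whereas this result shows that the ring can carry trifluoromethyl on an aromatic carbon, meta to a large group, without a readable shift in the number. No measurement of any other kind bears on this result.

The compounds shown test one group at one place on this ring, so it remains open whether an amine, a carboxylic acid or a nitrile there would also stay within the scatter. Also open, as far as these compounds go, is whether trifluoromethyl at another place on the benzoyl ring would do the same.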